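From cyclohexylamino to hexylsulfanyl on the shared core

The source may report more compounds than this note shows. Statements on the series, on what has been measured and on what is new or still open speak of the compounds shown alone.

Measured in an ADME assay on CCRF-HSB-2 cells (Homo sapiens) for cytotoxicity, with a stated time of 7 days; a higher number here means that more compound is tolerated, a lower number that less compound is tolerated:
- Compound 1 `Nc1nc(OCC(F)(F)F)c2ncn(/C=C3/CC3(CO)CO)c2n1`: > 20000 nM (a limit)
- Compound 2 `Nc1nc(NC2CCCCC2)c2ncn(/C=C3/CC3(CO)CO)c2n1`: > 20000 nM (a limit)

Compound 2 gives only a limit, > 20000 nM, and no number. Compound 3 `CCCCCCSc1nc(N)nc2c1ncn2/C=C1/CC1(CO)CO` carries hexylsulfanyl in place of cyclohexylamino on an aromatic carbon. For the measured compounds named here, the only measured step that bears on this, a step that the two limits leave unreadable from compound 1 to compound 2, also exchanges a group on an aromatic carbon, but its size cannot be read. Going by the values given here, the sole guide is the limit of > 20000 nM in this assay, at which 2 of the 2 values shown sit. The expected step in this assay is therefore a number no higher from compound 2 to compound 3 (the limit leaves the size open), with no change beyond the scatter anticipated. Compound 3 is expected at 20000 nM, with an estimated range of 7000 nM to 40000 nM.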

Compound 3, half-maximal cytotoxic concentration: 60000 nM
Compound 3: middle estimate off by 3.0-fold (0.48 log units), on the low side, and the stated range ends below it.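

Compound 1 and compound 2 stand only as limits, so neither step from them to compound 3 can be read. The compounds shown leave open how far hexylsulfanyl, in place of cyclohexylamino or 2,2,2-trifluoroethoxy, moves the value in this assay.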